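The source may report more compounds than this note shows. Statements on the series, on what has been measured and on what is new or still open speak of the compounds shown alone.

Compound 2 `COc1cccnc1Nc1cc2[nH]c(-c3cccc(C(F)(F)F)c3)nc2cn1` stands second highest of the three numbers in an ADME assay on microsomes from liver (Homo sapiens) for metabolic stability, read by LC-MS, with a stated time of 30 min, tested at 0.1 uM (a lower number here means that less of the compound is left, a higher number that more of the compound is left), where compound 2 gives 69%. Compound 1 `FC(F)(F)Oc1ccc(-c2nc3cnc(Nc4ccccn4)cc3[nH]2)cc1` gives 60%, which lies within the scatter of compound 2, while compound 3 `COc1ccnc(Nc2cc3[nH]c(-c4cccc(C(F)(F)F)c4)nc3cn2)c1` gives 80%. For the measured compounds named here, the only measured step at this position, a number 11 percentage points higher from compound 2 to compound 3 (beyond the scatter), came with 4-methoxypyridin-2-yl in place of 3-methoxypyridin-2-yl on a nitrogen on an aromatic ring. Compound 4 `FC(F)(F)c1cccc(-c2nc3cnc(Nc4cccnn4)cc3[nH]2)c1` instead carries pyridazin-3-yl in place of 3-methoxypyridin-2-yl on a nitrogen on an aromatic ring. Going by the values given here, no measured pair covers a pyridazin-3-yl at this place, so the step from compound 2 to compound 3 is only a loose guide, and at most a modest shift is expected. The estimate for compound 4 is 70%, with a range from 50% to 88%. This amounts to an expected step of a number 1 percentage points higher from compound 2 to compound 4 (within the scatter), which would stay within the scatter.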

Compound 4, percent of the compound remaining: 84%
For compound 4 the middle estimate is 14 percentage points below the measured one, and the stated range covers the measured number.
By their numbers in this assay, from the lowest: compounds 1 and 2 (each within the scatter of the next); then compounds 3 and 4 (each within the scatter of the next).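

Pyridazin-3-yl in place of 3-methoxypyridin-2-yl on a nitrogen on an aromatic ring gave a number 15 percentage points higher from compound 2 to compound 4 (beyond the scatter), so in this assay this position does not need a methoxy group to keep a high number. Against the 4-methoxypyridin-2-yl group the change gave a number 4 percentage points higher from compound 3 to compound 4 (within the scatter), which leaves the two groups indistinguishable here. Nothing available accounts for either step. Open, as far as these compounds go, is how a pyridazin-3-yl carrying an amine or a methoxy group would fare at this place, and whether the result holds with a trifluoromethoxy group in place of the trifluoromethyl group.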